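The source may report more compounds than this note shows. Statements on the series, on what has been measured and on what is new or still open speak of the compounds shown alone.

The set concerns four amides built on a shared core. Compound 1 `COC1CN(C(=O)/C=C/c2ccncc2-c2ccc3ccccc3c2)C1` is the starting point of this account. In a functional assay on A549 cells (Homo sapiens) for inhibition, read by sulforhodamine B assay, with a stated time of 72 h (a higher number here means a weaker inhibitor of growth, a lower number a stronger inhibitor of growth), compound 1 gives > 10000 nM, which is a limit of the assay and not a measured number. Compound 2 `CNC(=O)/C=C/c1ccncc1-c1ccc2[nH]ccc2c1` belongs to the same series; in this assay compound 2 gives > 10000 nM, again only a limit. Compound 3 `O=C(CCc1ccncc1-c1ccc2ccccc2c1)N1CCOCC1` completes the measured set; in this assay compound 3 gives > 10000 nM, also a limit. Compound 1 therefore stands exactly where the other two stand, and no order among the three can be read from the numbers, as the limit of > 10000 nM in this assay, at which 3 of the 3 values shown sit, makes plain.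

Compound 4 `CN1CCN(C(=O)/C=C/c2ccncc2-c2ccc3ccccc3c2)CC1` has not yet been measured. It differs from compound 1 in one place: 4-methylpiperazin-1-yl in place of 3-methoxyazetidin-1-yl on a carbonyl carbon. Among the compounds with values here, no pair of measured compounds carries this same change, so its effect is unknown, and the measured values give no clue about direction.

Since all three measured values sit at the limit (the limit of > 10000 nM in this assay, at which 3 of the 3 values shown sit), compound 4 is expected to stay at or near that limit as well. The step that the limit leaves unreadable from compound 1 to compound 4 is expected to be small, with no change beyond the scatter being the most likely outcome. Compound 4 is estimated to give 20000 nM, with a range from 5000 nM to 100000 nM.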

Compound 4, concentration for 50% growth inhibition: > 10000 nM
Compound 4 gave a limit, no number; the forecaster's own chance of this, stated with the estimate: 80%; the middle value does not contradict the limit.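

In this assay compound 4 gives > 10000 nM, which is a limit and not a number. No step can be read between compound 1 and compound 4, as both values are limits: the limit of > 10000 nM in this assay, at which 4 of the 4 values shown sit. The compounds shown leave open whether 4-methylpiperazin-1-yl in place of 3-methoxyazetidin-1-yl on a carbonyl carbon changes growth inhibition at all.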